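This account rests on a few compounds, and the source may have more. Where it says the series, first, only, none or still open, it means among the compounds named here.

Of the compounds shown here, three sharing one core have been measured in an in vitro functional assay on HEK285-7 cells for antagonist activity at prostaglandin D2 receptor 2 (Homo sapiens), read by BRET and beta-arrestin recruitment; on this read-out higher numbers stand for larger maximal responses and lower numbers for smaller maximal responses. Compound 1 `O=C(O)Cc1sc(C(c2ccc(F)cc2)c2ccc(F)cc2)nc1-c1cc(F)cc(F)c1` gives 80% in this assay. Compound 2 `O=C(O)Cc1sc(C(c2ccccc2)c2ccc(F)c(F)c2)nc1-c1ccc(F)cc1` gives 80%, and compound 3 `COc1ccc(C(c2ccccc2)c2nc(-c3ccc(Cl)cc3)c(CC(=O)O)s2)cc1` gives 80%. Compound 1 thus stands level with compound 2 and with compound 3 at the digits reported; the gaps in either direction lie within the scatter of repeated measurements, so no ranking among the three can be read from these numbers.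

Compound 4 `CN(C)c1cc(-c2nc(C(c3ccc(F)cc3)c3ccc(F)cc3)sc2CC(=O)O)ccn1` has not yet been measured in this assay. It differs from compound 1 in one place: 2-(dimethylamino)pyridin-4-yl in place of 3,5-difluorophenyl on an aromatic carbon. For the measured compounds named here, no pair of measured compounds differing in a single place is available to calibrate the size of such a change. Across compounds 1, 2 and 3 the aryl groups around the shared core vary while the maximal response stays at one level, so a step of a number 2 percentage points lower from compound 1 to compound 4 (within the scatter) is expected, that is, none beyond the scatter. Compound 4 is accordingly estimated to reach 78%, within a range of 60% to 95%.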

Compound 4, largest response reached (reported as efficacy), in percent of the reference or control that the assay uses: 80%
The estimate for compound 4 lay 2 percentage points below the measured number; the range from low to high includes it.
By their numbers in this assay, from the lowest: compounds 1, 2, 3 and 4 (each within the scatter of the next).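

In this assay, replacing 3,5-difluorophenyl with 2-(dimethylamino)pyridin-4-yl on the aromatic carbon next to the ring nitrogen gives no change at the digits printed from compound 1 to compound 4 (within the scatter). For the compounds shown here, this is the only single-place step in the set, and it shows that at this position the maximal response stays level when a carbon-only ring with 0 hydrogen-bond acceptors gives way to a ring with 1 hetero atom and 2 hydrogen-bond acceptors. No supporting measurement is available to explain this result.

As far as these compounds go, whether the level holds with a morpholine or a cyclohexyl group on this aromatic carbon remains open, as does what an unsubstituted pyridin-4-yl would show about the dimethylamino group. With all four compounds at one level, the compounds shown do not reveal which change at this position, if any, would shift the maximal response.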